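A few compounds are considered here, and "the series" means these few. Any claim that something is new, unique, unknown or untested is made for them only; others in the source may bear on it.

Series notes. Compound 1 `CCS(=O)(=O)Nc1ccc(-c2cc(=O)c3c(O)cc(OC)c(OC(C)C)c3o2)cc1` is the reference point: in a functional assay on LNCaP cells (Homo sapiens) for antiproliferative activity, read by MTT assay, with a stated time of 3 days (on this read-out lower numbers stand for stronger inhibition and higher numbers for weaker inhibition), compound 1 gives 113000 nM. Compound 2 `COc1cc(O)c2c(=O)cc(-c3ccc(NC(=O)NC4CC4)cc3)oc2c1OC(C)C` carries cyclopropylcarbamoyl in place of ethylsulfonyl on a nitrogen on an aromatic ring, and in this assay compound 2 gives 13800 nM. That step is an 8.2-fold lower number from compound 1 to compound 2 (0.91 log units; beyond the scatter). On the two numbers shown, compound 2 stands lowest, with compound 1 as its only neighbour, beyond the scatter.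

Compound 3 `COc1cc(O)c2c(=O)cc(-c3ccc(NC(=O)N4CCN(C)CC4)cc3)oc2c1OC(C)C` is not yet measured. It differs from compound 2 in one place: 4-methylpiperazin-1-yl in place of cyclopropylamino on a carbonyl carbon. A single measured step exists, and it bears on compound 3 only indirectly: it exchanged the group on the nitrogen on the aromatic ring, ethylsulfonyl for cyclopropylcarbamoyl, and was modest in size. The carbamoyl that step introduced remains in compound 3; what changes is the group on the carbonyl carbon. Going by the values given here, no measured pair shows such an exchange, so the direction cannot be read from the data. The expectation for compound 3 in this assay is therefore a step of a 1.1-fold higher number from compound 2 to compound 3 (0.04 log units; within the scatter), meaning nothing beyond the scatter. Compound 3 is estimated at 15000 nM, with a range from 5000 nM to 45000 nM.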

Compound 3, half-maximal inhibitory concentration: 4500 nM
The estimate for compound 3 lay 3.3-fold (0.52 log units) above the measured number; the measured number lies below the stated range.
By their numbers in this assay, from the lowest: compound 3; then compound 2; then compound 1.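

The group on the carbonyl carbon proves to be a second place that moves the number in this assay: 4-methylpiperazin-1-yl in place of cyclopropylamino gives a 3.1-fold lower number from compound 2 to compound 3 (0.49 log units; beyond the scatter) on top of the earlier exchange on the nitrogen on the aromatic ring. Going by these compounds alone, measured against ethylsulfonyl, the full (4-methylpiperazin-1-yl)carbonyl group gives a 25-fold lower number from compound 1 to compound 3 (1.40 log units; beyond the scatter) and is the only large step, leaving compound 3 lowest of the three. No measurement offered here accounts for this fall in the number.

The exchange alters several counted features at once: ring size, hetero atoms, and the hydrogen-bond donor present in cyclopropylamino and absent from 4-methylpiperazin-1-yl, so the step cannot be assigned to any one of them. Morpholin-4-yl, unsubstituted piperazin-1-yl or an open-chain dimethylamino on the same carbonyl carbon would separate the contributions of the second ring nitrogen, its methyl group and the ring itself, and the shown compounds leave open how far the number can fall at this place.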